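Benzyl variation on the shared core: toward compound 4

The compounds below may be only part of what the source reports. "The series", "measured", "known", "first", "only" and "open" are said of these compounds alone.

compound 1 `Cc1cccc(CN2Cc3c(NC(=O)c4ccccc4)n[nH]c3C2(C)C)c1` — in an assay on Sf21 cells for inhibition of high affinity nerve growth factor receptor (Homo sapiens), read by HTRF, with a stated time of 30 min, in the presence of a further agent that is not named here (a higher number here means a weaker inhibitor, a lower number a stronger inhibitor), compound 1 gives 1100 nM
compound 2 `CC1(C)c2[nH]nc(NC(=O)c3ccccc3)c2CN1Cc1cccc(Br)c1` — in this assay compound 2 gives 940 nM
compound 3 `CC1(C)c2[nH]nc(NC(=O)c3ccccc3)c2CN1Cc1cccc(Cl)c1` — in this assay compound 3 gives 670 nM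

Compound 3 carries the lowest number of the three, but the steps to it are small: a 1.6-fold lower number from compound 1 to compound 3 (0.22 log units; within the scatter) and a 1.4-fold lower number from compound 2 to compound 3 (0.15 log units; within the scatter) are both within the scatter, as is a 1.2-fold lower number from compound 1 to compound 2 (0.07 log units; within the scatter). The three benzyl variants therefore read as one level, and compound 3 cannot be called the strongest of them.

Compound 4 `CC1(C)c2[nH]nc(NC(=O)c3ccccc3)c2CN1Cc1ccccc1F` differs from compound 3 by 2-fluorophenyl in place of 3-chlorophenyl on a saturated chain carbon bound to an amine nitrogen in a ring. Within the data shown here, none of the measured steps covers this change; they swap one group for another on a single aromatic carbon of the benzyl group, and all of them stay within the scatter. Whether the new group behaves like the three measured ones is not known from these data. On what is measured, no step beyond the scatter is expected in this assay. For compound 4 the expected step is a 1.3-fold higher number from compound 3 to compound 4 (0.13 log units; within the scatter), with the range widened for the untested change. Compound 4 is expected to give 900 nM in this assay, between 400 nM and 2200 nM.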

Compound 4, half-maximal inhibitory concentration: 450 nM
The estimate for compound 4 lay 2.0-fold (0.30 log units) above the measured number; low and high end bracket the measured number.
By their numbers in this assay, from the lowest: compounds 4, 3, 2 and 1 (each within the scatter of the next, the first and the last beyond it).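

In this assay, the change to 2-fluorobenzyl gives the only steps beyond the scatter among the compounds shown: a 2.1-fold lower number from compound 2 to compound 4 (0.32 log units; beyond the scatter) and a 2.4-fold lower number from compound 1 to compound 4 (0.39 log units; beyond the scatter), both modest. Against the chloro analogue the same change stays level, with a 1.5-fold lower number from compound 3 to compound 4 (0.17 log units; within the scatter), so compound 3 and compound 4 read as one level, and 2-fluorophenyl on a saturated chain carbon bound to an amine nitrogen in a ring keeps the activity of the series. Nothing measured bears on the origin of these steps.

How 2-chlorobenzyl and 3-fluorobenzyl would read is open, and with them whether the halogen or its place on the benzyl group goes with the steps. Also open, going by these compounds, is how unsubstituted benzyl or 2-methoxybenzyl compares with compound 4 in this assay.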